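Aminophenyl to difluorophenyl on the carbonyl carbon

A few compounds are considered here, and "the series" means these few. Any claim that something is new, unique, unknown or untested is made for them only; others in the source may bear on it.

Compound 1 `COc1cc(-c2cc(/C=C/C(=O)c3ccc(N)cc3)[nH]n2)cc(OC)c1OC` has the lowest number of the three measured in a functional assay on SF-268 cells (Homo sapiens) for inhibition, read by sulforhodamine B assay, with a stated time of 48 h (a higher number here means that more compound is tolerated, a lower number that less compound is tolerated), where compound 1 gives 9160 nM. Compound 2 `COc1ccc(-c2cc(/C=C/C(=O)c3ccc(N)cc3)[nH]n2)cc1OC` gives 11200 nM and compound 3 `COc1ccc(-c2cc(/C=C/C(=O)c3ccc(N)cc3)[nH]n2)cc1` gives 45700 nM. The step of a 1.2-fold higher number from compound 1 to compound 2 (0.09 log units; within the scatter) lies within the scatter, while the step of a 4.1-fold higher number from compound 2 to compound 3 (0.61 log units; beyond the scatter) lies beyond it. Both concern hydrogen in place of methoxy on an aromatic carbon and leave the carbonyl side untouched. Compound 4 `COc1cc(-c2cc(/C=C/C(=O)c3ccc(F)c(F)c3)[nH]n2)cc(OC)c1OC` differs from compound 1 by 3,4-difluorophenyl in place of 4-aminophenyl on a carbonyl carbon. Among the compounds with values here, no measured step touches the 4-aminophenyl group, so the data give no direction for this change. The expected step is therefore a 1.0-fold lower number from compound 1 to compound 4 (0.01 log units; within the scatter), not beyond the scatter, with a wide range. Compound 4 is expected to give 9000 nM, between 3000 nM and 30000 nM.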

Compound 4, concentration lethal to 50% of the cells: > 100000 nM
Compound 4 gave a limit, no number; the forecaster's own chance of this, stated with the estimate: 10%; at least 11-fold (1.04 log units) between middle value and limit.
By their numbers in this assay, from the lowest: compounds 1 and 2 (each within the scatter of the next); then compound 3. At a limit, above all of these: compound 4.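

On the core of compound 1, the carbonyl side proves decisive in this assay: 3,4-difluorophenyl in place of 4-aminophenyl on a carbonyl carbon gives an at least 10-fold higher number from compound 1 to compound 4 (1.03 log units; beyond the scatter). The value of compound 4 is a limit and not a number: the limit of > 100000 nM in this assay, at which 1 of the 4 values shown sits. Within this pair, 4-aminophenyl goes with a measurable number and 3,4-difluorophenyl does not.

This single exchange cannot separate loss of the amine from entry of the two fluorines. An unsubstituted phenyl group or an acetamide in place of the amine would bear on that question.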